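The source may report more compounds than this note shows. Statements on the series, on what has been measured and on what is new or still open speak of the compounds shown alone.

Measured compounds:
compound 1, `CO[C@]1(c2ccc(OCc3c(-c4c(Cl)cccc4Cl)noc3C3CC3)cc2Cl)C[C@H](c2cccc(C(=O)O)c2)C1`: 93%
compound 2, `Clc1cc(OCc2c(-c3c(Cl)cccc3Cl)noc2C2CC2)ccc1C1CC1c1ccc(-c2nnn[nH]2)nc1`: 101%

In an assay on isolated protein for agonist activity at Bile acid receptor (Homo sapiens), read by FRET (on this read-out higher numbers stand for larger maximal responses and lower numbers for smaller maximal responses), compound 1 gives 93%, the lower of the two numbers at hand, although the gap to compound 2 is within the scatter: compound 2 gives 101%, so the two compounds cannot be told apart on this read-out. Compound 3, `O=C(O)c1cccc([C@H]2C[C@](OCCO)(c3ccc(OCc4c(-c5c(Cl)cccc5Cl)noc4C4CC4)cc3Cl)C2)c1`, has not been measured yet. It differs from compound 1 in a single place: hydroxymethyl in place of hydrogen on a saturated chain carbon bound to an oxygen on a saturated carbon. Within the data shown here, no pair of measured compounds shows what such a change does; the two values in hand only show that both measured compounds reach a near-full maximal response. Since compound 1 already sits at 93%, the step of a number 2 percentage points higher from compound 1 to compound 3 (within the scatter) is expected to remain within the scatter, with no clear direction up or down. Compound 3 is therefore estimated to give 95% in this assay, with a range from 80% to 110%.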

Compound 3, largest response reached (reported as efficacy), in percent of the reference or control that the assay uses: 97%
Compound 3: the middle estimate sits 2 percentage points below what was measured; low and high end bracket the measured number.
By their numbers in this assay, from the lowest: compounds 1, 3 and 2 (each within the scatter of the next).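

In this assay, among these compounds, exchanging methoxy for 2-hydroxyethoxy gives a step of a number 4 percentage points higher from compound 1 to compound 3 (within the scatter), the first view of a change at this place in the molecule. Hydroxymethyl in place of hydrogen on a saturated chain carbon bound to an oxygen on a saturated carbon therefore leaves the maximal response indistinguishable from that of compound 1, so this position accepts a chain ending in a hydroxyl group without a readable change in this measure. This single pair cannot show how far that acceptance extends. Open, going by these compounds, is whether a longer chain, such as 3-hydroxypropoxy, or a chain ending in an amine would also keep this response. Also open, on these data alone, is how much of each compound is needed to reach it. No measurement at hand explains the outcome of this change.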